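Fluorine on the anilide ring: lipophilicity estimate for compound 4

This account rests on a few compounds, and the source may have more. Where it says the series, first, only, none or still open, it means among the compounds named here.

Measured compounds:
compound 1, `COc1ccc2nc(C)cc(OCC(=O)Nc3cc(C)cc(C)c3)c2c1`: 5.64
compound 2, `Cc1cc(C)cc(NC(=O)COc2cc(C)nc3ccc(OC(F)(F)F)cc23)c1`: 6.79
compound 3, `COc1ccc2nc(C)cc(OCC(=O)Nc3c(C)cccc3C)c2c1`: 4.55

All three compounds were run in a physicochemical assay for lipophilicity, read by HPLC, in phosphate buffer, measured as chromatographic lipophilicity, at pH 7.4; on this read-out lower numbers stand for lower lipophilicity and higher numbers for higher lipophilicity. Compound 3 stands lowest of the three; its nearest neighbour is compound 1 with a number 1.09 log units lower from compound 1 to compound 3 (beyond the scatter) separating them, and compound 2 lies furthest away. The other measured step, a number 1.15 log units higher from compound 1 to compound 2 (beyond the scatter), concerns the group on the oxygen of the shared core and does not touch the anilide ring.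

Compound 4 is `COc1ccc2nc(C)cc(OCC(=O)Nc3cc(C)c(F)c(C)c3)c2c1`. It differs from compound 3 in one place: 4-fluoro-3,5-dimethylphenyl in place of 2,6-dimethylphenyl on an amide-type nitrogen. The step from compound 1 to compound 3 bears on this change directly, because a number 1.09 log units lower from compound 1 to compound 3 (beyond the scatter) measures the move from 3,5-dimethylphenyl to 2,6-dimethylphenyl, and compound 4 reverses that move while adding one fluorine to the ring. Among the compounds with values here, no measured pair in this set isolates a single fluorine on an aromatic carbon, so that part of the change carries no measured precedent and only a small upward allowance is made for it.

Compound 4 is therefore expected to sit close to compound 1 in this assay, a little higher. The estimate for compound 4 is 5.85, in the range 5.4 to 6.3, which means an expected step of a number 1.30 log units higher from compound 3 to compound 4 (beyond the scatter).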

Compound 4, distribution coefficient: 5.5
For compound 4 the middle estimate is 0.35 log units above the measured one; measured number inside the range.
By their numbers in this assay, from the lowest: compound 3; then compounds 4 and 1 (each within the scatter of the next); then compound 2.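

In this assay, within the data shown here, the step of a number 0.14 log units lower from compound 1 to compound 4 (within the scatter) is the first read on fluoro in place of hydrogen on an aromatic carbon, and it leaves compound 1 and compound 4 not distinguishable on this read-out. The step of a number 0.95 log units higher from compound 3 to compound 4 (beyond the scatter) stands beside the step of a number 1.09 log units lower from compound 1 to compound 3 (beyond the scatter) and places 2,6-dimethylphenyl apart from both 3,5-dimethylphenyl and 4-fluoro-3,5-dimethylphenyl on the amide-type nitrogen, so among these compounds the separation goes with the 2,6-dimethylphenyl group and no separation goes with the added fluoro. No measured information on these compounds accounts for either step.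

Going by these compounds, whether a chloro, a nitrile, a methoxy or an amine in place of that fluoro would also stay within the scatter of compound 1 remains open. Also open, on these data alone, is whether the same fluoro change gives a similar result on the trifluoromethyl-bearing core of compound 2, since one pair on one core gives no general rule for this aryl group.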